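The source may report more compounds than this note shows. Statements on the series, on what has been measured and on what is new or still open speak of the compounds shown alone.

Compound 1 `Cc1cc(Nc2cc(N3CCN(C)CC3)nc(Nc3ccc(Cl)cc3)n2)n[nH]1`: 1610 nM
Compound 2 `Cc1cc(Nc2cc(N3CCN(C)CC3)nc(Nc3cccc([N+](=O)[O-])c3)n2)n[nH]1`: 2180 nM

Among the measured compounds shown here, in a functional assay on SK-BR-3 cells (Homo sapiens) for antiproliferative activity, read by CCK-8 assay, with a stated time of 72 h (a higher number here means a weaker inhibitor, a lower number a stronger inhibitor), compound 1 gives 1610 nM, and its only comparison is compound 2, which lies within the scatter of it. Compound 3 `COc1ccc(Nc2nc(Nc3cc(C)[nH]n3)cc(N3CCN(C)CC3)n2)cc1` differs from compound 1 in one place: methoxy in place of chloro on an aromatic carbon. For the measured compounds named here, the single measured step that touches this same aryl group is a 1.4-fold higher number from compound 1 to compound 2 (0.13 log units; within the scatter). It is one step with a different substituent, so it is thin evidence, and no change beyond the scatter is expected in this assay. The estimated step is a 1.1-fold higher number from compound 1 to compound 3 (0.05 log units; within the scatter). For compound 3 the estimated value is 1800 nM, with an expected range of 700 nM to 4500 nM.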

Compound 3, half-maximal inhibitory concentration: 14700 nM
Compound 3: middle estimate off by 8.2-fold (0.91 log units), on the low side; measured number outside the range, above it.
By their numbers in this assay, from the lowest: compounds 1 and 2 (each within the scatter of the next); then compound 3.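

In this assay, the substituent on this aryl group proves able to shift the number beyond the scatter, which the earlier pair did not show: methoxy in place of chloro gives a 9.1-fold higher number from compound 1 to compound 3 (0.96 log units; beyond the scatter). The 4-methoxyphenyl group also stands apart from 3-nitrophenyl, with a 6.7-fold higher number from compound 2 to compound 3 (0.83 log units; beyond the scatter), so the shift does not depend on chloro as the reference. The data at hand offer no explanation for this shift. As far as these compounds go, whether a hydroxy or an amine at this aromatic carbon would fall with chloro or with methoxy stays open.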